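A few compounds are considered here, and "the series" means these few. Any claim that something is new, unique, unknown or untested is made for them only; others in the source may bear on it.

Two measured compounds share one core. Compound 1 `CCCCCc1ccc(NS(=O)(=O)c2ccc(N3CCNC3=O)cc2)cc1` carries a pentyl group on an aromatic carbon, and compound 2 `COc1ccc(NS(=O)(=O)c2ccc(N3CCNC3=O)cc2)cc1` carries a methoxy group in its place. In a functional assay on MCF7 cells (Homo sapiens) for antiproliferative activity, read by sulforhodamine B assay, with a stated time of 48 h (on this read-out higher numbers stand for weaker inhibition and lower numbers for stronger inhibition), compound 1 gives > 1000 nM, which is a limit of the assay rather than a number. In this assay compound 2 likewise gives > 1000 nM, again a limit. The step that the two limits leave unreadable from compound 1 to compound 2 therefore cannot be read, since (the limit of > 1000 nM in this assay, at which 2 of the 2 values shown sit). On the numbers shown, compound 2 stands at that limit, with no finer placing possible.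

Compound 3 `O=C1NCCN1c1ccc(S(=O)(=O)Nc2ccc(F)c(F)c2)cc1` is the next compound. It differs from compound 2 by 3,4-difluorophenyl in place of 4-methoxyphenyl on a sulfonamide nitrogen. Going by the values given here, no measured step involves this exchange; the only recorded step, from pentyl to methoxy, is unreadable, so nothing shows how large a change in this assay this difference should bring, nor in which direction. The step that the limit leaves unreadable from compound 2 to compound 3 is therefore expected to be near zero. Compound 3 is expected to sit at about 2500 nM, within a range from 500 nM to 12000 nM, and most likely again to be reported only as a limit.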

Compound 3, half-maximal inhibitory concentration: 620 nM
The estimate for compound 3 lay 4.0-fold (0.61 log units) above the measured number; the measured number falls inside the stated range.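

Going by these compounds alone, compound 3 is the first compound here to give a number rather than a limit, so the group on the sulfonamide nitrogen is a place where a change can bring the read-out into measurable range. In this assay, within the data shown here, 3,4-difluorophenyl in place of 4-methoxyphenyl gives an at least 1.6-fold lower number from compound 2 to compound 3 (0.20 log units; that floor lies within the scatter), and this is the first sign of a direction for any exchange, though a floor within the scatter is only a weak sign. Compound 2 remains a limit rather than a number, so the step has a floor but no known full size: the limit of > 1000 nM in this assay, at which 2 of the 3 values shown sit.

The compounds shown do not tell whether both fluorines are needed, or whether a single fluorine, a chlorine, a nitrile or an amine on that aromatic ring would give a lower or a higher number. They also leave open why the number changes with this exchange and whether any change to the shared core, such as a longer chain or a carboxylic acid on it, would move the read-out further.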